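This account rests on a few compounds, and the source may have more. Where it says the series, first, only, none or still open, it means among the compounds named here.

Measured compounds:

- compound 1 `COc1ccc(S(=O)(=O)Nc2ccc3oc(-c4ccc(NS(=O)(=O)c5cc(F)ccc5OC)cc4)nc3c2)cc1` gives in an assay on isolated protein for inhibition of thiosulfate sulfurtransferase (Homo sapiens) (a higher number here means a weaker inhibitor, a lower number a stronger inhibitor), a limit of > 100000 nM, not a number.
- compound 2 `O=S(=O)(Nc1ccc(-c2nc3cc(NS(=O)(=O)c4ccc(Br)cc4)ccc3o2)cc1)c1ccc(Br)cc1` gives in this assay a limit of > 100000 nM.
- compound 3 `Nc1ccc(S(=O)(=O)Nc2ccc(-c3nc4cc(NS(=O)(=O)c5ccc(N)cc5)ccc4o3)cc2)cc1` gives in this assay a limit of > 100000 nM.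

None of the three compounds gives a number in this assay; each sits at the limit of the measurement, so compound 1 cannot be placed above or below compound 2 or compound 3, and all three stand together at the limit of > 100000 nM in this assay, at which 3 of the 3 values shown sit. That is all the shown data say about compound 1.

Compound 4 `COc1ccc(S(=O)(=O)Nc2ccc(-c3nc4cc(NS(=O)(=O)c5ccc(OC)cc5)ccc4o3)cc2)cc1` has not yet been measured in this assay. It comes from compound 1 by one change on a sulfonyl sulfur whose other neighbours are a sulfonamide nitrogen: 4-methoxyphenyl in place of 5-fluoro-2-methoxyphenyl on a sulfonyl sulfur.

Among the compounds with values here, since every measured compound sits at the limit, there is no measured step of any size to lean on. The expectation is that the step that the limit leaves unreadable from compound 1 to compound 4 brings no change beyond the scatter, with compound 4 most likely again reported only as a limit. Compound 4 is therefore estimated at 150000 nM in this assay, within a range of 30000 nM to 1000000 nM.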

Compound 4, half-maximal inhibitory concentration: > 100000 nM
Compound 4: no number, only a limit (the forecaster's own chance of this, stated with the estimate: 85%); the middle value is on the limit's open side.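

Compound 1 and compound 4 are both reported only as a limit in this assay, so no step between them can be read: the limit of > 100000 nM in this assay, at which 4 of the 4 values shown sit.

The compounds shown leave open whether any change on a sulfonyl sulfur would give an actual number in this assay.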